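A 1,1-difluoroethyl group replaces fluoro in a clearance series

The source may report more compounds than this note shows. Statements on the series, on what has been measured and on what is new or still open speak of the compounds shown alone.

- compound 1 `O=C(NCCCCc1ccccc1)c1cccc(C2SCC(=O)N2c2cccc(-c3c[nH]nn3)c2)c1` gives 226 mL.min-1.g-1
- compound 2 `C#Cc1cccc(N2C(=O)CSC2c2cccc(C(=O)NCCCCc3ccccc3)c2)c1` gives 973 mL.min-1.g-1
- compound 3 `O=C(NCCCCc1ccccc1)c1cccc(C2SCC(=O)N2c2cccc(F)c2)c1` gives 837 mL.min-1.g-1

These values all come from an ADME assay on microsomes from liver (Canis lupus familiaris) for metabolic stability, read by LC-MS, using NADPH, with a stated time of 10 min, tested at 0.1 uM (a lower number here means slower removal, a higher number faster removal of the compound), and place compound 3 second highest of the three. Compound 3, at 837 mL.min-1.g-1 here, lies within the scatter of compound 2, at 973 mL.min-1.g-1 here, and clearly above compound 1, at 226 mL.min-1.g-1 on the same scale.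

The next compound is compound 4 `CC(F)(F)c1cccc(N2C(=O)CSC2c2cccc(C(=O)NCCCCc3ccccc3)c2)c1`, which carries 1,1-difluoroethyl in place of fluoro on an aromatic carbon. The difference is this: 1,1-difluoroethyl in place of fluoro on an aromatic carbon and the rest of the molecule is unchanged.

For the measured compounds named here, three measured steps concern the same aromatic carbon. Two are modest and start from compound 1: a 4.3-fold higher number from compound 1 to compound 2 (0.63 log units; beyond the scatter) and a 3.7-fold higher number from compound 1 to compound 3 (0.57 log units; beyond the scatter) are the steps away from 1H-1,2,3-triazol-4-yl. The third, a 1.2-fold lower number from compound 2 to compound 3 (0.07 log units; within the scatter), stays within the scatter. None of them involves 1,1-difluoroethyl, so the data give no direct measure of this group. Taking that third step as the closest guide, no step beyond the scatter is expected in this assay for the new group. The expected size is a 1.1-fold higher number from compound 3 to compound 4 (0.03 log units; within the scatter) and no more. Compound 4 is estimated at 900 mL.min-1.g-1 within an expected range from 480 mL.min-1.g-1 to 1700 mL.min-1.g-1 in this measurement.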

Compound 4, intrinsic clearance in microsomes: 912 mL.min-1.g-1
Compound 4: the middle estimate sits 1.0-fold (0.01 log units) below what was measured; the range from low to high includes it.
By their numbers in this assay, from the lowest: compound 1; then compounds 3, 4 and 2 (each within the scatter of the next).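

In this assay the change from fluoro to 1,1-difluoroethyl on this aromatic carbon, with its larger count of heavy atoms, gives a 1.1-fold higher number from compound 3 to compound 4 (0.04 log units; within the scatter) and the comparison with ethynyl gives a 1.1-fold lower number from compound 2 to compound 4 (0.03 log units; within the scatter) so three different groups at this position now stand at one level within the scatter, and the added size of the new group leaves no readable mark on the number. Against the same position carrying 1H-1,2,3-triazol-4-yl, the new group gives a 4.0-fold higher number from compound 1 to compound 4 (0.61 log units; beyond the scatter) which makes compound 1 the only one of the four apart from the others, and a third replacement now repeats the gap that ethynyl and fluoro had already shown. Nothing available explains why the groups fall out this way.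

Still open, going by these compounds, is whether the lower number belongs to the triazole alone or would also appear with other groups on this carbon, such as an amine, a carboxylic acid or an imidazole. On these data alone, it is equally open whether the shared level would hold for a longer chain such as 2,2,2-trifluoroethyl, or for a change elsewhere in the shared core.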